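Chain extension on the shared core: compound 3 to compound 4

This account rests on a few compounds, and the source may have more. Where it says the series, first, only, none or still open, it means among the compounds named here.

Three members of the series have numbers in an assay on CHO cells for displacement of a labelled ligand from prostaglandin D2 receptor 2 (Homo sapiens), read by scintillation counting; on this read-out lower numbers stand for stronger inhibition and higher numbers for weaker inhibition. Compound 3 `CCCc1ccncc1C#Cc1cc(Cl)ccc1OCC(=O)O` gives 4.3 nM. Compound 1 `CC(C)Cc1ccncc1C#Cc1cc(Cl)ccc1OCC(=O)O` gives 4.9 nM, and the step of a 1.1-fold lower number from compound 1 to compound 3 (0.06 log units; within the scatter). Compound 2 `CC(C)(C)N1C(=O)c2ccc(C#Cc3cc(Cl)ccc3OCC(=O)O)cc2S1(=O)=O`, built on a different core, gives 14 nM, a higher number beyond the scatter from compound 3. Compound 3 thus holds the lowest number of the three, with compound 1 within the scatter of it and compound 2 beyond.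

Compound 4 `CCCCCCc1ccncc1C#Cc1cc(Cl)ccc1OCC(=O)O` carries the change (propyl in place of hydrogen on a saturated chain carbon, three bonds along the chain from an aromatic carbon); cut one bond further out, the same difference reads propyl to hexyl. Within the data shown here, the only measured step on the chain at this position is the one from compound 1 to compound 3, which removed a methyl and stayed within the scatter; no measured pair adds a propyl. That single step gives no direction, and the uncertainty rests on the longer chain itself, for which nothing in the series speaks. The expectation for compound 4 leans slightly toward a higher number but stays close to what the series has shown: the estimate is 6 nM, between 2 nM and 20 nM. The step of a 1.4-fold higher number from compound 3 to compound 4 (0.14 log units; within the scatter) is expected to lie within the scatter.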

Compound 4, inhibition constant: 43 nM
Compound 4: the middle estimate sits 7.2-fold (0.86 log units) below what was measured, and the stated range ends below it.
By their numbers in this assay, from the lowest: compounds 3 and 1 (each within the scatter of the next); then compound 2; then compound 4.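

In this assay, among these compounds, this position proves sensitive to chain length, which the earlier compounds did not reveal: the earlier step of a 1.1-fold lower number from compound 1 to compound 3 (0.06 log units; within the scatter) stayed within the scatter, whereas propyl in place of hydrogen on a saturated chain carbon, three bonds along the chain from an aromatic carbon, gives a 10-fold higher number from compound 3 to compound 4 (1.00 log units; beyond the scatter). The comparison with the branched chain points the same way, with pentyl in place of isopropyl on a saturated chain carbon bound to an aromatic carbon giving an 8.8-fold higher number from compound 1 to compound 4 (0.94 log units; beyond the scatter), also beyond the scatter, so the agreement between the two shorter chains does not extend to the hexyl chain. Nothing available speaks to the reason for this rise.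

The compounds shown hold no butyl or pentyl chain at this position, which leaves open whether the number climbs steadily from propyl to hexyl or jumps at one particular length. Also open, going by these compounds, is whether the rise follows from chain length alone, a question that a hexyl-length chain ending in a hydroxyl or an amine, or a cyclohexyl group, could address.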